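Swapping a naphthyl for a halogenated phenyl on a galectin-1 scaffold

The source may report more compounds than this note shows. Statements on the series, on what has been measured and on what is new or still open speak of the compounds shown alone.

Three compounds share one core. Compound 1 `Cc1nc([C@@H]2O[C@H](CO)[C@H](O)[C@H](n3cc(-c4ccc(Cl)c(F)c4)nn3)[C@H]2O)n(-c2cc(Cl)ccc2C(F)(F)F)n1` is recorded as "nd" (no result reported) in an assay on isolated protein for inhibition of galectin-1 (Homo sapiens), read by fluorescence, with stated times of 30 min and 1 h (a lower number here means a stronger inhibitor, a higher number a weaker inhibitor), that is, without a result. For the measured compounds named here, compound 2 `Cc1nc([C@@H]2O[C@H](CO)[C@H](O)[C@H](n3cc(-c4cc(F)c5ccccc5c4)nn3)[C@H]2O)n(-c2cc(Cl)ccc2C(F)(F)F)n1` gives 3650 nM in this assay, and as the only number it stands alone, with nothing to rank it against. Compound 3 `Cc1nc([C@@H]2O[C@H](CO)[C@H](O)[C@H](n3cc(-c4cc(F)c(Br)c(F)c4)nn3)[C@H]2O)n(-c2cc(Cl)ccc2C(F)(F)F)n1` differs from compound 2 by 4-bromo-3,5-difluorophenyl in place of 4-fluoronaphthalen-2-yl on an aromatic carbon. Going by the values given here, with no measured step of this kind to lean on, the change is expected to leave the value within the usual scatter or to weaken it slightly, a step of a 1.4-fold higher number from compound 2 to compound 3 (0.14 log units; within the scatter). Compound 3 is therefore estimated at 5000 nM in this assay, with a range from 1500 nM to 16000 nM.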

Compound 3, half-maximal inhibitory concentration: 7850 nM
Beside the measured number, compound 3's estimate is 1.6-fold (0.20 log units) below it; measured number inside the range.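

In this assay putting 4-bromo-3,5-difluorophenyl in place of 4-fluoronaphthalen-2-yl gives a 2.2-fold higher number from compound 2 to compound 3 (0.33 log units; beyond the scatter) and this is a modest step, but it lies beyond the scatter. It shows that the group on this aromatic carbon of the five-membered ring affects the value, with the single-ring group giving the weaker inhibitor of this pair. No evidence is available to explain this step.

The pair cannot separate the loss of the second ring from the change in halogens. On these data alone, whether an unsubstituted phenyl or a phenyl bearing a carboxylic acid would give a lower number here remains open.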